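Methyl to methoxy on two related cores

A few compounds are considered here, and "the series" means these few. Any claim that something is new, unique, unknown or untested is made for them only; others in the source may bear on it.

Compound 1 `Cc1ccc(C2CC(c3ccccc3)=NN2c2ccccc2)cc1` and compound 2 `COc1ccc(C2CC(c3ccccc3)=NN2c2ccccc2)cc1` share one core; compound 3 `Cc1ccc(-c2cc(-c3ccccc3)nn2-c2ccccc2)cc1` and compound 4 `COc1ccc(-c2cc(-c3ccccc3)nn2-c2ccccc2)cc1` share a second. The difference between the two cores is not broken down here. In an assay for inhibition of cathepsin H (Capra hircus), using Lineweaver-Burk analysis (a lower number here means a stronger inhibitor, a higher number a weaker inhibitor), compound 1 gives 4180 nM and compound 2 gives 2120 nM. The change between them, (methoxy in place of methyl on an aromatic carbon), gave a 2.0-fold lower number from compound 1 to compound 2 (0.29 log units; within the scatter). Compound 3 gives 7400 nM, the highest of the three numbers, within the scatter of compound 1 but beyond it against compound 2.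

Compound 4 carries the same change on the second core: methoxy in place of methyl on an aromatic carbon. The place is described in the same words for both pairs, so this is the same change, not merely the same kind. Within the data shown here, only one measured example of it exists, and that step lay within the scatter, so a small shift is the expectation here, not a firm one. For compound 4 the expected step is a 2.0-fold lower number from compound 3 to compound 4 (0.30 log units; within the scatter), resting on the earlier step of the same size. Compound 4 is estimated at 3700 nM, with a likely range from 1800 nM to 8000 nM.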

Compound 4, inhibition constant: 3330 nM
Beside the measured number, compound 4's estimate is 1.1-fold (0.05 log units) above it; low and high end bracket the measured number.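

In this assay, methoxy in place of methyl on an aromatic carbon gives a 2.2-fold lower number from compound 3 to compound 4 (0.35 log units; beyond the scatter), so on the second core the change acts in the same direction and with a size matching that on the first: the same change on two cores in this assay, a 2.0-fold lower number (0.29 log units; within the scatter) from compound 1 to compound 2 and a 2.2-fold lower number (0.35 log units; beyond the scatter) from compound 3 to compound 4, 1.1-fold (0.05 log units) apart, within the scatter of two such steps

For this series, the agreement supports carrying this one change between these two cores, at this one place, as a modest step of predictable size. Among these compounds, it rests on only two pairs, though, and one of those two steps lies within the scatter. It shows nothing about why the two steps agree, and it does not show that any other change would transfer between the cores in the same way.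

Still open, going by these compounds, is what other groups at the same place would do, for instance an amine, a carboxylic acid or a longer chain such as butoxy in place of methoxy. On these data alone, the other aromatic rings carry no group in any of the four compounds, so the effect of substitution there also remains open.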